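A few compounds are considered here, and "the series" means these few. Any claim that something is new, unique, unknown or untested is made for them only; others in the source may bear on it.

In an ADME assay on HepG2 cells (Homo sapiens) for cytotoxicity, read by CellTiter-Glo, with a stated time of 72 h (on this read-out higher numbers stand for an effect only at larger amounts of compound and lower numbers for an effect already at smaller amounts), three compounds sharing one core have been measured. Compound 1 `C/C1=C/C2=C[C@H](C)C[C@@]23O[C@]2(CC(C)(C)[C@@H](O)[C@@H]2C1=O)[C@@H](C)C3=O` gives 26000 nM, compound 2 `CO[C@H]1[C@@H]2C(=O)/C(C)=C\C3=C[C@H](C)C[C@@]34O[C@]2(CC1(C)C)[C@@H](C)C4=O` gives 26000 nM, and compound 3 `C/C1=C/C2=C[C@H](C)C[C@@]23O[C@]2(CC(C)(C)[C@@H](OC(C)C)[C@@H]2C1=O)[C@@H](C)C3=O`, which carries an isopropoxy group, gives 26000 nM. Compound 3 therefore stands level with compound 1 and compound 2 at the digits reported.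

Compound 4 `C/C1=C/C2=C[C@H](C)C[C@@]23O[C@]2(CC(C)(C)[C@@H](Nc4ccccc4)[C@@H]2C1=O)[C@@H](C)C3=O` departs from compound 3 through anilino in place of isopropoxy on a saturated ring carbon.

Among the compounds with values here, three measured steps bear on this change. Methyl in place of hydrogen on the oxygen shows no change at the digits printed from compound 1 to compound 2 (within the scatter). Isopropyl in place of hydrogen shows no change at the digits printed from compound 1 to compound 3 (within the scatter), and isopropyl in place of methyl shows no change at the digits printed from compound 2 to compound 3 (within the scatter). All three alter only the group on that oxygen. Within the data shown here, none replaces the oxygen with nitrogen or brings in an aromatic ring, so the data offer no direct precedent for anilino.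

The flat steps give no ground for predicting a direction, although the missing precedent leaves room for a real shift. The expected step in this assay is a 1.3-fold lower number from compound 3 to compound 4 (0.11 log units; within the scatter), which is none beyond the scatter. The estimated value for compound 4 is 20000 nM, with an expected range from 8000 nM to 40000 nM.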

Compound 4, half-maximal effective concentration: 26000 nM
The estimate for compound 4 lay 1.3-fold (0.11 log units) below the measured number; the measured number falls inside the stated range.
By their numbers in this assay, from the lowest: compounds 1, 2, 3 and 4 (each within the scatter of the next).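

In this assay anilino in place of isopropoxy gives no change at the digits printed from compound 3 to compound 4 (within the scatter) and anilino in place of methoxy gives no change at the digits printed from compound 2 to compound 4 (within the scatter) while anilino in place of hydroxy gives no change at the digits printed from compound 1 to compound 4 (within the scatter) on the same saturated ring carbon. The earlier steps shown here altered only the group on the oxygen, whereas these replace that oxygen-linked group with a nitrogen-linked one and bring in a six-membered aromatic ring of carbon only, so the flat picture at this position now covers a change of the attached atom and a much larger group as well. No evidence is available to explain why the read-out stays the same across these groups.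

Still open, from the compounds shown here alone, is whether any group on this ring carbon would move the number, for example a carboxylic acid, a simple primary amine, a longer alkyl chain on the oxygen, or an anilino carrying a chlorine on its aromatic ring. All four compounds shown differ only at this one carbon, so the effect of changing the carbonyl groups or the two methyl groups elsewhere on the shared core also remains open.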